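Hydroxy in place of methoxy: expecting compound 3

The source may report more compounds than this note shows. Statements on the series, on what has been measured and on what is new or still open speak of the compounds shown alone.

Measured so far:
compound 1 `O=C(Nc1cccc(-n2cc(-c3ccncc3)c(-c3ccc(Cl)c(O)c3)n2)c1)Nc1cccc(C(F)(F)F)c1`, 20000 nM
compound 2 `COc1cc(-c2nn(-c3cccc(NC(=O)Nc4cc(C(F)(F)F)cc(C(F)(F)F)c4)c3)cc2-c2ccncc2)ccc1Cl`, 3970 nM

In a functional assay on SR cells (Homo sapiens) for inhibition, read by sulforhodamine B assay, with a stated time of 48 h (a lower number here means a stronger inhibitor of growth, a higher number a weaker inhibitor of growth), compound 2 gives 3970 nM, the lowest of the two numbers. Compound 1 gives 20000 nM, a higher number, and that gap is beyond the scatter. Compound 3 `O=C(Nc1cccc(-n2cc(-c3ccncc3)c(-c3ccc(Cl)c(O)c3)n2)c1)Nc1cc(C(F)(F)F)cc(C(F)(F)F)c1` differs from compound 2 by hydrogen in place of methyl on an oxygen on an aromatic ring. Going by the values given here, no measured pair shows this change alone, so its size is open. Compound 1 carries the same hydroxy. Because compound 1 gives 20000 nM a step toward weaker inhibition of growth is expected for compound 3, a 2.0-fold higher number from compound 2 to compound 3 (0.30 log units; within the scatter). Compound 3 is estimated at 8000 nM, within 2500 nM to 25000 nM.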

Compound 3, concentration for total growth inhibition: 3660 nM
For compound 3 the middle estimate is 2.2-fold (0.34 log units) above the measured one; the range from low to high includes it.
By their numbers in this assay, from the lowest: compounds 3 and 2 (each within the scatter of the next); then compound 1.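

In this assay, methoxy to hydroxy on the 4-chloro-3-methoxyphenyl group gives a 1.1-fold lower number from compound 2 to compound 3 (0.04 log units; within the scatter), so with two trifluoromethyl groups present, this change does not separate compound 2 from compound 3. Trifluoromethyl in place of hydrogen on an aromatic carbon gives a 5.5-fold lower number from compound 1 to compound 3 (0.74 log units; beyond the scatter), so the higher number of compound 1 goes with the missing trifluoromethyl, not with the hydroxy that compound 3 also carries. No measurement given here accounts for either step.

Going by these compounds, whether methoxy to hydroxy behaves the same with a single trifluoromethyl remains open. Also open, on these data alone, is how an amine or an ethoxy group in place of the hydroxy would read.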